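The compounds below may be only part of what the source reports. "The series", "measured", "known", "first", "only" and "open" are said of these compounds alone.

Measured so far:
compound 1, `C[C@H]1CC[C@@H]2[C@@H](OC(=O)[C@]23CC(c2c(Cl)cccc2Cl)=NO3)[C@]2(C)C(=O)C=C[C@@]12O`: 38000 nM
compound 2, `C[C@H]1CC[C@@H]2[C@@H](OC(=O)[C@]23CC(c2ccccc2)=NO3)[C@]2(C)C(=O)C=C[C@@]12O`: 39800 nM

In a functional assay on DU-145 cells (Homo sapiens) for cytotoxicity, read by sulforhodamine B assay, with a stated time of 48 h (a higher number here means a weaker inhibitor, a lower number a stronger inhibitor), compound 2 gives 39800 nM. For the measured compounds named here, the only other number comes from compound 1, which gives 38000 nM; the two are separated by a 1.0-fold higher number from compound 1 to compound 2 (0.02 log units; within the scatter), so compound 2 stands alongside compound 1 rather than apart from it. The shared core is the same in both, and the aryl group at the carbon with the double bond to nitrogen is the only part that has been varied.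

Compound 3 is `C[C@H]1CC[C@@H]2[C@@H](OC(=O)[C@]23CC(c2ccc(F)cc2)=NO3)[C@]2(C)C(=O)C=C[C@@]12O`. It differs from compound 2 as follows: fluoro in place of hydrogen on an aromatic carbon. Going by the values given here, the one measured step, a 1.0-fold higher number from compound 1 to compound 2 (0.02 log units; within the scatter), shows that a substantial change of the substitution on that ring left the number unmoved; no step specifically concerns fluoro in place of hydrogen, so its effect is not known from these data. Given that the aryl variation already seen produced no shift, the step from compound 2 to compound 3 is expected to be small, a 1.1-fold lower number from compound 2 to compound 3 (0.04 log units; within the scatter), with no clear direction.

Compound 3 is therefore estimated at 36000 nM, with a range from 15000 nM to 90000 nM.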

Compound 3, half-maximal inhibitory concentration: 13000 nM
The estimate for compound 3 lay 2.8-fold (0.44 log units) above the measured number, outside the stated range (below it).
By their numbers in this assay, from the lowest: compound 3; then compounds 1 and 2 (each within the scatter of the next).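

In this assay the aryl group on the carbon with the double bond to nitrogen no longer looks like a position where changes leave the number unmoved: fluoro in place of hydrogen, para to a large group on the six-membered aromatic ring, gives a 3.1-fold lower number from compound 2 to compound 3 (0.49 log units; beyond the scatter), a modest step but one beyond the scatter. The change from 2,6-dichlorophenyl to 4-fluorophenyl gives a similar result, a 2.9-fold lower number from compound 1 to compound 3 (0.47 log units; beyond the scatter), whereas the change from 2,6-dichlorophenyl to phenyl had stayed within the scatter, a 1.0-fold higher number from compound 1 to compound 2 (0.02 log units; within the scatter), so the substitution on this ring can move the number even though that first change did not. No supporting measurement is available to account for this shift.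

From the compounds shown here alone, it remains open whether the shift is particular to fluoro, or whether chloro, methoxy or an amine in that same place would side with compound 3 or stand with compounds 1 and 2. The compounds shown also leave open whether fluoro elsewhere on the ring, or a second fluoro, would move the number further.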